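From a 2-hydroxyethyl to a 5-hydroxypentyl chain

The source may report more compounds than this note shows. Statements on the series, on what has been measured and on what is new or still open speak of the compounds shown alone.

Compound 2 `COc1nc2ccc(Br)cc2cc1C(c1ccccc1)n1cc(CCO)nn1` stands lowest of the two compounds measured in an ADME assay on HeLa cells (Homo sapiens) for cytotoxicity, read by sulforhodamine B assay, with a stated time of 48 h, tested at 10 uM (on this read-out lower numbers stand for less inhibition and higher numbers for more inhibition at the one concentration tested (going by the name of the read-out)), where compound 2 gives 0.85%. Its nearest neighbour is compound 1 `COc1nc2ccc(Br)cc2cc1C(c1ccccc1)n1cc(-c2ccc(Br)cc2)nn1`, which in this assay gives 6.92%; the step of a number 6.1 percentage points lower from compound 1 to compound 2 (within the scatter) lies within the scatter. Compound 3 `COc1nc2ccc(Br)cc2cc1C(c1ccccc1)n1cc(CCCCCO)nn1` differs from compound 2 in one place: 3-hydroxypropyl in place of hydroxy on a saturated chain carbon, two bonds along the chain from an aromatic carbon. Going by the values given here, no measured step covers this change, and the only step available stays within the scatter, so compound 3 is expected to show a step of a number 1.2 percentage points higher from compound 2 to compound 3 (within the scatter). Compound 3 is therefore estimated at 2% in this assay, with a range from -5% to 10%.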

Compound 3, a percentage reported as inhibition, at one concentration (the size of the read-out at that concentration, not a potency): 1.08%
For compound 3 the middle estimate is 0.9 percentage points above the measured one, and the stated range covers the measured number.
By their numbers in this assay, from the lowest: compounds 2, 3 and 1 (each within the scatter of the next).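

In this assay the 5-hydroxypentyl chain in place of the 2-hydroxyethyl chain gives a number 0.2 percentage points higher from compound 2 to compound 3 (within the scatter), so extending the chain at this position leaves no difference that can be read. The same holds for 5-hydroxypentyl in place of 4-bromophenyl on the aromatic carbon, which gives a number 5.8 percentage points lower from compound 1 to compound 3 (within the scatter), so the aryl group and both hydroxyalkyl chains cannot be told apart here. Nothing available explains why these numbers lie so close together. Going by these compounds, whether an amine or a carboxylic acid in place of the terminal hydroxy, or a longer chain, would separate from these compounds in this assay remains open.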